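Compound 4: Amino in Place of Dimethylamino on the Chain

This account rests on a few compounds, and the source may have more. Where it says the series, first, only, none or still open, it means among the compounds named here.

Three compounds have been measured:

Compound 1, `CC(C)c1n[nH]c2c(NCc3ccc(-c4ccccn4)cc3)nc(SCC(C)(C)O)nc12`, gives 507 nM in a functional assay on HT cells (Homo sapiens) for antiproliferative activity, read by fluorescence, with a stated time of 72 h; a higher number here means a weaker inhibitor of growth, a lower number a stronger inhibitor of growth.
Compound 2, `CSc1nc(NCc2ccc(-c3ccccn3)cc2)c2[nH]nc(C(C)C)c2n1`, gives 783 nM in this assay.
Compound 3, `CC(C)c1n[nH]c2c(NCc3ccc(-c4ccccn4)cc3)nc(SCCCN(C)C)nc12`, gives 105 nM in this assay.

Compound 3 stands lowest of the three numbers, and both of its steps from the other two lie beyond the scatter: a 4.8-fold lower number from compound 1 to compound 3 (0.68 log units; beyond the scatter) and a 7.5-fold lower number from compound 2 to compound 3 (0.87 log units; beyond the scatter). The step between compound 1 and compound 2 is small, a 1.5-fold higher number from compound 1 to compound 2 (0.19 log units; within the scatter), so the gain in compound 3 accompanies the group at the end of the chain on the sulfur.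

Compound 4, `CC(C)c1n[nH]c2c(NCc3ccc(-c4ccccn4)cc3)nc(SCCCN)nc12`, carries a single change relative to compound 3: amino in place of dimethylamino on a saturated chain carbon, three bonds along the chain from a sulfur. Among the compounds with values here, no measured step reproduces this change exactly; the two steps that bear on it, from compound 1 and from compound 2 to compound 3, show only that a 2-(dimethylamino)ethyl terminus lowers the number compared with 1-hydroxy-1-methylethyl or hydrogen. Since compound 4 keeps a nitrogen at that end of the chain, its number is expected to stay close to that of compound 3, with the step of a 1.4-fold higher number from compound 3 to compound 4 (0.15 log units; within the scatter) expected to fall within the scatter. Compound 4 is therefore estimated at 150 nM, with a range from 50 nM to 450 nM.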

Compound 4, concentration for 50% growth inhibition: 120 nM
Beside the measured number, compound 4's estimate is 1.3-fold (0.10 log units) above it; measured number inside the range.
By their numbers in this assay, from the lowest: compounds 3 and 4 (each within the scatter of the next); then compounds 1 and 2 (each within the scatter of the next).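

In this assay, amino and dimethylamino at the end of the chain cannot be told apart (a 1.1-fold higher number from compound 3 to compound 4 (0.06 log units; within the scatter)), so the methyl groups of the dimethylamino group are not required for the low number seen with compound 3. The advantage over the other two side chains on the sulfur also holds with the amino terminus (a 6.5-fold lower number from compound 2 to compound 4 (0.81 log units; beyond the scatter); a 4.2-fold lower number from compound 1 to compound 4 (0.63 log units; beyond the scatter)), which means that the low numbers are shared by 3-aminopropyl and 3-(dimethylamino)propyl rather than being confined to the latter. Nothing available here accounts for this equivalence, and no measurement bears on why the two termini give such similar numbers.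

The compounds shown leave open whether the nitrogen itself is what matters at the end of the chain, a question that a plain propyl chain or a carboxylic acid in that place would address. They also leave open how far the result extends to a methylamino terminus, a cyclic amine such as pyrrolidine, or a longer or shorter chain between the sulfur and the amine.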